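The compounds below may be only part of what the source reports. "The series", "measured", "known", "first", "only" and "open" are said of these compounds alone.

Working notes on the series. The shared core carries at the saturated chain carbon bound to an oxygen on an aromatic ring a side chain that is varied across the set. Compound 1 `CC(=O)NC[C@H]1CN(c2ccc(OC[C@@H](O)CNc3ccccc3)c(F)c2)C(=O)O1` gives in a physicochemical assay for lipophilicity, read by HPLC (on this read-out higher numbers stand for higher lipophilicity and lower numbers for lower lipophilicity), 1.42. Compound 2 `CC(=O)NC[C@H]1CN(c2ccc(OC[C@@H](O)CNc3ccc(C#N)cc3)c(F)c2)C(=O)O1` gives in this assay 2.12; the step of a number 0.70 log units higher from compound 1 to compound 2 (beyond the scatter) is a cyano in place of hydrogen on an aromatic carbon. Compound 3 `CC(=O)NC[C@H]1CN(c2ccc(OC[C@H](O)CNc3cccnc3)c(F)c2)C(=O)O1` gives in this assay -0.18, the lowest of the three numbers; the step of a number 1.60 log units lower from compound 1 to compound 3 (beyond the scatter) puts a pyridin-3-ylamino group in place of the anilino group. Compound 4 `CC(=O)NC[C@H]1CN(c2ccc(OC[C@@H](O)CNC3CC3)c(F)c2)C(=O)O1` is not yet measured. It differs from compound 3 by 2-(cyclopropylamino)-1-hydroxyethyl in place of 1-hydroxy-2-((pyridin-3-yl)amino)ethyl on a saturated chain carbon bound to an oxygen on an aromatic ring. Among the compounds with values here, no measured step swaps an aromatic amine for a cyclopropylamine; the only step touching this side chain, from compound 1 to compound 3, is large and downward, and that of compound 1 to compound 2 is a change on the distant aromatic ring. The expected step of a number 0.42 log units lower from compound 3 to compound 4 (beyond the scatter) in this assay is therefore uncertain and may not lie beyond the scatter. Compound 4 is estimated at -0.6 in this assay, with a range from -1.6 to 0.4.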

Compound 4, partition coefficient: 0.02
Compound 4: middle estimate off by 0.62 log units, on the low side; the measured number falls inside the stated range.
By their numbers in this assay, from the lowest: compounds 3 and 4 (each within the scatter of the next); then compound 1; then compound 2.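

On the amine nitrogen of this side chain, the three-membered non-aromatic ring of compound 4 and the pyridin-3-yl ring of compound 3 cannot be told apart in this assay, the swap giving a number 0.20 log units higher from compound 3 to compound 4 (within the scatter). Against the aromatic carbon rings on the same nitrogen, cyclopropyl gives a number 1.40 log units lower from compound 1 to compound 4 (beyond the scatter) and a number 2.10 log units lower from compound 2 to compound 4 (beyond the scatter), both large, so a side chain without any aromatic ring sits with compound 3, well apart from compound 1 and compound 2, and an aromatic ring on this nitrogen does not by itself set the read-out. Nothing measured on hand accounts for any of these steps.

Open, from the compounds shown here alone, is whether a longer alkyl chain such as n-butyl, or a larger saturated ring such as cyclohexyl, on this amine nitrogen would stay with compound 3 and compound 4 or move towards compound 1. Also open, going by these compounds, is whether a cyano group on the pyridin-3-yl ring would give a step like the one seen on the phenyl ring in a number 0.70 log units higher from compound 1 to compound 2 (beyond the scatter).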